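A few compounds are considered here, and "the series" means these few. Any claim that something is new, unique, unknown or untested is made for them only; others in the source may bear on it.

Three members of the series have numbers in a functional assay on MDA-MB-468 cells (Homo sapiens) for inhibition, read by CCK-8 assay and cell counting, with a stated time of 2 days; a lower number here means a stronger inhibitor, a higher number a weaker inhibitor. Compound 1 `O=C(/C=C/c1ccco1)c1cccc(OCC2CO2)c1` gives 37300 nM. Compound 2 `O=C(/C=C/c1cccs1)c1cccc(OCC2CO2)c1` gives 16300 nM. Compound 3 `O=C(/C=C/c1ccc(OCC(O)CCl)cc1)c1ccco1` gives 9530 nM, the lowest of the three; its gap to compound 2 lies within the scatter, its gap to compound 1 beyond it. Among the measured compounds shown here, the one counted step so far is a 2.3-fold lower number from compound 1 to compound 2 (0.36 log units; beyond the scatter), the change being (thiophen-2-yl in place of furan-2-yl on a double-bonded chain carbon bound to a double-bonded chain carbon).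

Compound 4 `O=C(/C=C/c1ccc(OCC(O)CCl)cc1)c1cccs1` is not yet measured. It differs from compound 3 by thiophen-2-yl in place of furan-2-yl on a carbonyl carbon. The difference between the core of compound 1 and the core of compound 3 is not broken down here. The change from compound 3 to compound 4 is the same kind of change as that from compound 1 to compound 2, but at a different place: on a carbonyl carbon whose other neighbours are a double-bonded chain carbon, rather than on a double-bonded chain carbon bound to a double-bonded chain carbon. For the measured compounds named here, the step is expected to be a 1.7-fold lower number from compound 3 to compound 4 (0.24 log units; within the scatter), resting on the single earlier instance in compound 1 and compound 2, and held loosely because a 2.3-fold lower number from compound 1 to compound 2 (0.36 log units; beyond the scatter) is modest and sits at another place. Compound 4 is estimated at 5500 nM, with a range from 2500 nM to 12000 nM.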

Compound 4, half-maximal inhibitory concentration: 7750 nM
Compound 4: middle estimate off by 1.4-fold (0.15 log units), on the low side, and the stated range covers the measured number.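

In this assay, thiophen-2-yl in place of furan-2-yl on a carbonyl carbon gives a 1.2-fold lower number from compound 3 to compound 4 (0.09 log units; within the scatter), so this pair cannot be told apart. Set beside the earlier instance of the same change, this step does not differ measurably from it: the same change on two cores in this assay, a 2.3-fold lower number (0.36 log units; beyond the scatter) from compound 1 to compound 2 and a 1.2-fold lower number (0.09 log units; within the scatter) from compound 3 to compound 4, 1.9-fold (0.27 log units) apart, within the scatter of two such steps. The change therefore carries from one core to the other without a detectable difference in step size, but two pairs, with the change at a different place in each, do not show that the step size is the same on both cores or that it would hold on a further core.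

The compounds shown leave open whether an amine or a longer chain in place of the chloromethyl end of the side chain would shift the number in this assay. Among the compounds shown here, no single-place pair links the core of compound 1 to the core of compound 3, so the contribution of each structural difference between those cores also remains unresolved.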